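A few compounds are considered here, and "the series" means these few. Any claim that something is new, unique, unknown or untested is made for them only; others in the source may bear on it.

For the measured compounds named here, in a functional assay on HeLa cells (Homo sapiens) for antiproliferative activity, with a stated time of 5 days (a higher number here means a weaker inhibitor, a lower number a stronger inhibitor), compound 1 `Cc1ccc(-n2nc(-c3ccc4ccccc4c3)nc2N2C(=O)COC23C=CC(=O)C=C3)cc1` gives 150 nM and so holds the lower of the two numbers measured so far, while compound 2 `Cc1ccc(-n2nc(-c3ccc4ccccc4c3)nc2N2C(=O)C(C)OC23C=CC(=O)C=C3)cc1` gives 530 nM in the same read-out. Compound 3 `O=C1C=CC2(C=C1)OCC(=O)N2c1nc(-c2ccc3ccccc3c2)nn1-c1ccc(Cl)cc1` departs from compound 1 at a single place: chloro in place of methyl on an aromatic carbon which amounts to chloro in place of methyl on an aromatic carbon, turning 4-methylphenyl into 4-chlorophenyl. Going by the values given here, the only measured step is a 3.5-fold higher number from compound 1 to compound 2 (0.55 log units; beyond the scatter) for methyl in place of hydrogen on a saturated ring carbon. Among the compounds with values here, that step is modest, but it lies elsewhere in the molecule, and no measured pair tests the present change, so it gives compound 3 no direction. No shift beyond the scatter is therefore expected in this assay and the expected step is no change at the digits printed from compound 1 to compound 3 (within the scatter) with wide margins on either side. Compound 3 is estimated at 150 nM with an expected range from 50 nM to 450 nM as its upper end.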

Compound 3, half-maximal inhibitory concentration: 720 nM
The estimate for compound 3 lay 4.8-fold (0.68 log units) below the measured number, and the stated range ends below it.
By their numbers in this assay, from the lowest: compound 1; then compounds 2 and 3 (each within the scatter of the next).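

In this assay, for the compounds shown here, the aromatic carbon that carries the methyl of compound 1 proves sensitive to its substituent: chloro in place of methyl gives a 4.8-fold higher number from compound 1 to compound 3 (0.68 log units; beyond the scatter) and so provides the first measured reading at this position. On this core, 4-methylphenyl therefore gives the lower number and 4-chlorophenyl the higher one, by a modest margin that lies beyond the scatter. Nothing available accounts for this difference between the two groups.

The compounds shown leave open how other groups on this same aromatic carbon, such as methoxy, an amine or a longer chain like propyl, would read. They also leave open whether the same exchange of methyl for chloro would give a similar step on the core of compound 2.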